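The source may hold more compounds than are shown below. What is called first, only, known or untested is meant among the compounds shown, and "the series" means these compounds.

Measured compounds:
compound 1, `CN(C)CC[C@H](CSc1ccccc1)Nc1ccc(S(=O)(=O)NC(=O)c2ccc(N3CCN(Cc4ccccc4-c4ccc(Cl)cc4)CC3)cc2)cc1C(F)(F)F`, 2460 nM in a functional assay on NCI-H146 cells (Homo sapiens) for cytotoxicity, with a stated time of 48 h, in the presence of a further agent that is not named here; on this read-out higher numbers stand for an effect only at larger amounts of compound and lower numbers for an effect already at smaller amounts
compound 2, `CN(C)CC[C@H](CSc1ccccc1)Nc1ccc(S(=O)(=O)NC(=O)c2ccc(N3CCN(CC4=C(c5ccc(Cl)cc5)CCC(C)(C)C4)CC3)cc2)cc1[N+](=O)[O-]`, 98 nM in this assay

Compound 1 has the higher of the two numbers; compound 2 gives the lower one, and the gap between the two values is beyond the scatter. The two compounds differ in more than one place, so the numbers alone say nothing about any single change.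

Compound 3, `CN(C)CC[C@H](CSc1ccccc1)Nc1ccc(S(=O)(=O)NC(=O)c2ccc(N3CCN(Cc4ccccc4-c4ccc(Cl)cc4)CC3)cc2)cc1S(C)(=O)=O`, has not been measured in this assay. It differs from compound 1 in one place: methylsulfonyl in place of trifluoromethyl on an aromatic carbon. Among the measured compounds shown here, no measured step of this kind exists among the compounds here, so the expectation rests on compound 1 alone. A step from compound 1 to compound 3 of a 1.6-fold lower number from compound 1 to compound 3 (0.21 log units; within the scatter) is expected, small and toward a lower number, yet not clearly beyond the scatter. For compound 3 in this assay the estimate is 1500 nM, with a range from 400 nM to 5000 nM.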

Compound 3, half-maximal effective concentration: 34900 nM
Beside the measured number, compound 3's estimate is 23-fold (1.37 log units) below it; measured number outside the range, above it.
By their numbers in this assay, from the lowest: compound 2; then compound 1; then compound 3.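

In this assay, among the compounds shown here, methylsulfonyl in place of trifluoromethyl on this aromatic carbon, ortho to a large group and meta to a large group, gives a 14-fold higher number from compound 1 to compound 3 (1.15 log units; beyond the scatter) and is the first change here that can be read on its own. The number at this place therefore depends strongly on which group sits there, even though both groups have 4 heavy atoms and no net charge, and the entering group has 2 hydrogen-bond acceptors where the leaving group has 0. Nothing at hand bears on why the number moves in this direction.

From the compounds shown here alone, whether a nitrile or an amine on this carbon would give a number nearer to that of compound 1 or of compound 3 stays open. Also open, going by these compounds, is whether the same change would give a step of like size on the core of compound 2, which differs from compound 1 in more than one place.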